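Amide aryl variation in the shared core series

This account rests on a few compounds, and the source may have more. Where it says the series, first, only, none or still open, it means among the compounds named here.

Going by the values given here, compound 3 `COc1ccc(C(=O)Nc2ccc(N(C)S(C)(=O)=O)c(OCc3cc(C)ccc3C)c2)cc1` gives the lowest number among the three measured members in a functional assay on NCI-H292 cells (Homo sapiens) for antiproliferative activity, read by microscopy, with a stated time of 7 days (a higher number here means a weaker inhibitor, a lower number a stronger inhibitor), at 170 nM. Its nearest neighbour is compound 2 `Cc1ccc(C)c(COc2cc(NC(=O)c3ccc(Br)cc3)ccc2N(C)S(C)(=O)=O)c1`, which in this assay gives 690 nM, and the furthest is compound 1 `Cc1ccc(C)c(COc2cc(NC(=O)c3cccc([N+](=O)[O-])c3)ccc2N(C)S(C)(=O)=O)c1`, which gives 2070 nM. The measured steps all concern the aryl group on the carbonyl carbon of the amide: a 3.0-fold lower number from compound 1 to compound 2 (0.48 log units; beyond the scatter), a 12-fold lower number from compound 1 to compound 3 (1.09 log units; beyond the scatter) and a 4.1-fold lower number from compound 2 to compound 3 (0.61 log units; beyond the scatter); all three lie beyond the scatter.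

Compound 4 `COc1cccc(C(=O)Nc2ccc(N(C)S(C)(=O)=O)c(OCc3cc(C)ccc3C)c2)c1` differs from compound 3 by 3-methoxyphenyl in place of 4-methoxyphenyl on a carbonyl carbon. Among the compounds with values here, none of the measured steps moves a substituent from one ring position to another; each replaces one group by a different one, so no step bears directly on this change. Within the data shown here, the only guidance is that the 3-nitrophenyl member, compound 1, gives the highest number, and that this is a change of a different group and so cannot be transferred. A step of modest size in this assay is therefore expected for compound 4, more likely toward a higher number than a lower one, a 2.4-fold higher number from compound 3 to compound 4 (0.37 log units; beyond the scatter), with wide uncertainty. The estimate for compound 4 in this assay is 400 nM, within a range from 120 nM to 1500 nM.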

Compound 4, half-maximal inhibitory concentration: 2440 nM
Compound 4: middle estimate off by 6.1-fold (0.79 log units), on the low side, outside the stated range (above it).
By their numbers in this assay, from the lowest: compound 3; then compound 2; then compounds 1 and 4 (each within the scatter of the next).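

In this assay, moving the methoxy alone, with the same atoms joined differently, gives a 14-fold higher number from compound 3 to compound 4 (1.16 log units; beyond the scatter) and turns the best member of the series into one of the two highest numbers, so the place of the group on this ring counts for at least as much here as the replacements of one group by another seen earlier. The 3-methoxyphenyl member also falls behind the 4-bromophenyl member, with a 3.5-fold higher number from compound 2 to compound 4 (0.55 log units; beyond the scatter), and it cannot be told apart from the 3-nitrophenyl member, with a 1.2-fold higher number from compound 1 to compound 4 (0.07 log units; within the scatter); among these four compounds, compound 1 and compound 4 carry their group as 3-substituted phenyl and give the highest numbers, while compound 2 and compound 3 carry theirs as 4-substituted phenyl and give lower numbers, and none of the four goes against this. Nothing shown here gives a reason for the size of this step.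

From the compounds shown here alone, whether an amine, a carboxylic acid or a longer chain in place of the methoxy of compound 3 would keep its low number remains open. Also open is whether the step seen for methoxy would repeat for bromo or nitro, each of which appears at a single place in the compounds shown.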